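The source may hold more compounds than are shown below. What is called first, only, known or untested is meant among the compounds shown, and "the series" means these compounds.

Compound 1 `Cc1cccc2c1nc(COc1ccc(Cl)cc1)n2CCCC1CCNCC1`: 335 nM in an assay on AV12 cells for binding affinity to Neuropeptide Y receptor type 1 (Homo sapiens); on this read-out higher numbers stand for weaker inhibition and lower numbers for stronger inhibition
Compound 2 `Cc1cccc2c1nc(COc1ccc(Cl)cc1)n2CCCC1CCN(C)CC1`: 52 nM

Compound 2 holds the lower of the two numbers in this assay, with compound 1 the nearer neighbour by a 6.4-fold lower number from compound 1 to compound 2 (0.81 log units; beyond the scatter). Compound 3 `Cc1cccc2c1nc(COc1ccc(Cl)cc1)n2CCCC1CCN(CCCC(=O)O)CC1` follows on from compound 2 by 2-carboxyethyl in place of hydrogen on a saturated chain carbon bound to an amine nitrogen in a ring. For the measured compounds named here, only one measured step touches this part of the molecule, the substitution at the ring amine from compound 1 to compound 2, which gave a 6.4-fold lower number from compound 1 to compound 2 (0.81 log units; beyond the scatter). Going by the values given here, no measured pair shows what an extension of this kind, carrying a carboxylic acid, does at this position, so the earlier gain cannot simply be carried forward. Compound 3 is therefore estimated at 150 nM, within 40 nM to 600 nM, a step of a 2.9-fold higher number from compound 2 to compound 3 (0.46 log units; beyond the scatter) expected to be modest and upward, with the direction held only loosely.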

Compound 3, inhibition constant: 1630 nM
The estimate for compound 3 lay 11-fold (1.04 log units) below the measured number, and the stated range ends below it.
By their numbers in this assay, from the lowest: compound 2; then compound 1; then compound 3.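

The substituent on the ring amine nitrogen can move the number in either direction in this assay: exchanging methyl for 3-carboxypropyl gave a 31-fold higher number from compound 2 to compound 3 (1.50 log units; beyond the scatter) and more than reversed the earlier gain of methyl over hydrogen. Measured directly against the free amine, 3-carboxypropyl gave a 4.9-fold higher number from compound 1 to compound 3 (0.69 log units; beyond the scatter), so substitution at this nitrogen does not lower the number in itself, and the benefit seen with methyl does not extend to this longer, acid-bearing chain. Nothing measured here explains the loss. The change adds chain length and a carboxylic acid together, so the compounds shown do not separate their contributions. A plain butyl chain, or a methyl ester or primary amide at the end of the same chain, would help to tell them apart.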